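The source may report more compounds than this note shows. Statements on the series, on what has been measured and on what is new or still open speak of the compounds shown alone.

Values so far in an ADME assay on MT4 cells (Homo sapiens) for cytotoxicity, read by MTT assay, with a stated time of 96 h; on this read-out lower numbers stand for higher toxicity in this test and higher numbers for lower toxicity in this test
- compound 1 `NS(=O)(=O)c1ccc(N2N=C(c3ccc(OCc4ccccc4)cc3)CC2c2ccccc2Cl)cc1` gives 26000 nM
- compound 2 `NS(=O)(=O)c1ccc(N2N=C(c3ccc(Oc4ccccc4)cc3)CC2c2ccccc2Cl)cc1` gives 40000 nM

Within the data shown here, only these two numbers exist, and they lie within the scatter of each other, so compound 2 has no real separation from its single neighbour: a 1.5-fold higher number from compound 1 to compound 2 (0.19 log units; within the scatter).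

Compound 3 `NS(=O)(=O)c1ccc(N2N=C(c3ccc(Oc4ccccc4)cc3)CC2c2ccc(Cl)cc2)cc1` is the next point. It differs from compound 2 by 4-chlorophenyl in place of 2-chlorophenyl on a saturated ring carbon. Among the measured compounds shown here, no measured pair changes this part of the molecule. For the measured compounds named here, the one measured step is phenyl in place of benzyl on an oxygen on an aromatic ring, so it bears on the new change only indirectly, as a sign that the series has so far stayed within the scatter in this assay. The data give no direction for moving the chlorine, and the value of compound 2 at 40000 nM remains the only anchor.

The expected outcome is no step beyond the scatter, and the estimated step is a 1.1-fold lower number from compound 2 to compound 3 (0.06 log units; within the scatter). For compound 3 the estimated value is 35000 nM, with an expected range from 15000 nM to 80000 nM.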

Compound 3, half-maximal cytotoxic concentration: 9000 nM
Compound 3: the middle estimate sits 3.9-fold (0.59 log units) above what was measured; measured number below the stated range.
By their numbers in this assay, from the lowest: compound 3; then compounds 1 and 2 (each within the scatter of the next).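

In this assay, among these compounds, the saturated ring carbon is the first place where a change goes beyond the scatter: the swap of 2-chlorophenyl for 4-chlorophenyl gives a 4.4-fold lower number from compound 2 to compound 3 (0.65 log units; beyond the scatter) on that read-out, which means higher toxicity in this test. The leaving and entering groups have identical atom counts and differ only in how the atoms are joined, so the chlorine's placement on this phenyl group matters here, whereas the earlier phenyl-for-benzyl change on the oxygen stayed within the scatter. No measurement in hand explains why the 4-chlorophenyl compound separates from the 2-chlorophenyl compound.

The compounds shown do not reveal whether the chlorine itself is needed at this position, which an unsubstituted phenyl group would test, or whether a methoxyphenyl or fluorophenyl group would follow 4-chlorophenyl or 2-chlorophenyl. They also leave open whether the benzyl and phenyl groups on the oxygen would still lie within the scatter of each other with 4-chlorophenyl on the saturated ring carbon, since that comparison rests on 2-chlorophenyl alone.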